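Swapping a Thienylethyl Group for a Pentyl Chain

This account rests on a few compounds, and the source may have more. Where it says the series, first, only, none or still open, it means among the compounds named here.

Compound 2 `Cc1nc(N)sc1CCCN/C(N)=N/C(=O)NC(C)c1cccs1` and compound 1 `Cc1nc(N)sc1CCCN/C(N)=N/C(=O)NCC(C)CC1CCCCC1` share one core and differ only in the group on the amide-type nitrogen. In an assay on membranes from Sf9 cells for displacement of a labelled ligand from histamine H2 receptor (Homo sapiens), read by scintillation counting, with a stated time of 60 min (a higher number here means a weaker inhibitor, a lower number a stronger inhibitor), compound 2 gives 63.1 nM and compound 1 gives 70.8 nM; compound 2 has the lower of the two numbers, yet the gap is within the usual scatter. Compound 3 `CCCCCNC(=O)/N=C(\N)NCCCc1sc(N)nc1C` carries pentyl in place of 1-(thiophen-2-yl)ethyl on an amide-type nitrogen. Because compound 1 gives 70.8 nM with another chain in that place, a plain chain seems tolerated there. The step of a 2.1-fold higher number from compound 2 to compound 3 (0.31 log units; beyond the scatter) is expected to be a modest weakening, barely beyond the scatter. Compound 3 is thus estimated at 130 nM, ranging from 45 nM to 400 nM.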

Compound 3, inhibition constant: 4.47 nM
Estimate against measurement, compound 3: 29-fold (1.46 log units) above; the whole stated range lies above it.
By their numbers in this assay, from the lowest: compound 3; then compounds 2 and 1 (each within the scatter of the next).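

In this assay, the group on the amide-type nitrogen matters far more than the two earlier compounds suggested: pentyl in place of 1-(thiophen-2-yl)ethyl gives a 14-fold lower number from compound 2 to compound 3 (1.15 log units; beyond the scatter). The cyclohexyl-bearing chain gives way just as clearly, with a 16-fold lower number from compound 1 to compound 3 (1.20 log units; beyond the scatter), so a ring in this group is not needed for a low number. Nothing shown gives a reason for this gain. From the compounds shown here alone, whether a shorter chain such as propyl, a longer chain such as octyl, or a pentyl chain ending in an amine would keep this strength remains open.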